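Methyl in Place of Hydrogen on Compound 2

The source may report more compounds than this note shows. Statements on the series, on what has been measured and on what is new or still open speak of the compounds shown alone.

Going by the values given here, in a functional assay on HepG2 cells (Homo sapiens) for cytotoxicity, read by MTT assay, with a stated time of 48 h (on this read-out higher numbers stand for weaker inhibition and lower numbers for stronger inhibition), compound 2 `O=C(/C=C(/C=C/c1ccc(O)cc1)NCCCO)/C=C/c1ccc(O)cc1` gives 54100 nM as the only actual number so far. Compound 1 `COc1cc(/C=C/C2=CC(=O)CC(c3ccc(O)c(OC)c3)N2CCCO)ccc1O` gives only a limit of > 100000 nM in this assay and no number. Compound 3 `COCCCNC(=C\C(=O)/C=C/c1ccc(O)cc1)/C=C/c1ccc(O)cc1` carries a single change from compound 2 methyl in place of hydrogen on an oxygen on a saturated carbon (methyl in place of hydrogen on an oxygen on a saturated carbon, hydroxy to methoxy). Among the compounds with values here, no measured pair shows this change, so only a small 1.1-fold higher number from compound 2 to compound 3 (0.04 log units; within the scatter) is expected in this assay with no direction beyond the scatter. For compound 3 the estimated value is 60000 nM (expected range 25000 nM to 100000 nM).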

Compound 3, half-maximal inhibitory concentration: 61900 nM
Compound 3: the middle estimate sits 1.0-fold (0.01 log units) below what was measured; the measured number falls inside the stated range.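

Hydroxy to methoxy at this position gives a 1.1-fold higher number from compound 2 to compound 3 (0.06 log units; within the scatter) in this assay, the first measured pair to show this change. On this read-out, methyl and hydrogen on this oxygen cannot be told apart, as the two compounds lie within the scatter of each other.

From the compounds shown here alone, whether a longer chain on this oxygen, or an amine or a carboxylic acid in place of the hydroxy, would read the same remains open. Compound 1 offers only a limit and no number: the limit of > 100000 nM in this assay, at which 1 of the 3 values shown sits.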